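Adding a Methoxy Group to the Amine Compound

This account rests on a few compounds, and the source may have more. Where it says the series, first, only, none or still open, it means among the compounds named here.

Compound 1 and compound 2 have both been measured in an ADME assay on CCRF-CEM cells (Homo sapiens) for antiproliferative activity, with a stated time of 48 h; on this read-out lower numbers stand for stronger inhibition and higher numbers for weaker inhibition. Compound 1, `C=C(Br)C(=O)Nc1ccc(C(=O)/C=C/c2ccccc2OC)cc1`, gives 580 nM in this assay. Compound 2, `Nc1ccc(C(=O)/C=C/c2ccccc2)cc1`, gives 8500 nM in this assay, the highest of the pair; compound 1 lies far below it, a gap beyond the usual scatter. Compound 1 and compound 2 differ in more than one place, so their values cannot be tied to a single structural change. Compound 3, `COc1ccccc1/C=C/C(=O)c1ccc(N)cc1`, has not yet been measured. It differs from compound 2 by methoxy in place of hydrogen on an aromatic carbon. Among the compounds with values here, no single-change step between measured compounds is available to guide the expectation. In this assay the expected change is a 1.7-fold lower number from compound 2 to compound 3 (0.23 log units; within the scatter), a small move that may well stay within the scatter. Compound 3 is therefore estimated to give about 5000 nM in this assay, with a range from 1800 nM to 14000 nM.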

Compound 3, half-maximal inhibitory concentration: 6300 nM
Compound 3: middle estimate off by 1.3-fold (0.10 log units), on the low side, and the stated range covers the measured number.
By their numbers in this assay, from the lowest: compound 1; then compounds 3 and 2 (each within the scatter of the next).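

In this assay, methoxy in place of hydrogen on an aromatic carbon, ortho to a large group, gives a 1.3-fold lower number from compound 2 to compound 3 (0.13 log units; within the scatter), so with hydrogen on the nitrogen, compound 2 and compound 3 cannot be told apart. The nitrogen tells a different story: hydrogen in place of (1-bromoethenyl)carbonyl there gives an 11-fold higher number from compound 1 to compound 3 (1.04 log units; beyond the scatter), which makes this the only one of the two single changes whose step stands clear of the scatter. Nothing available here explains the size of either step.

From the compounds shown here alone, it remains open whether methoxy would count for as little with (1-bromoethenyl)carbonyl on the nitrogen. Also open, going by these compounds, is how a plain acetyl group on that nitrogen, or a hydroxyl group or a fluorine atom in place of the methoxy, would compare.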